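The source may report more compounds than this note shows. Statements on the series, on what has been measured and on what is new or still open speak of the compounds shown alone.

In an assay on isolated protein for binding affinity to corticotropin-releasing factor receptor 1 (Homo sapiens) (on this read-out higher numbers stand for weaker inhibition and lower numbers for stronger inhibition), the three measured compounds give:
compound 1 `CCCCN(CCC)c1cc(C)nc2c(-c3ncc(C(F)(F)F)cc3Cl)c(C)nn12`: 1.2 nM
compound 2 `CCCN(CCC)c1cc(C)nc2c(-c3ncc(C)cc3[N+](=O)[O-])c(C)nn12`: 14 nM
compound 3 `CCCN(CCC)c1cc(C)nc2c(-c3ncc(NC)cc3C)c(C)nn12`: 40 nM

Compound 3 stands highest of the three numbers; compound 2 is nearest, with a lower number beyond the scatter, and compound 1 is furthest, also lower and beyond the scatter. Compound 4 `CCCN(CCC)c1cc(C)nc2c(-c3ncc(F)cc3C)c(C)nn12` has not yet been measured. It differs from compound 3 in one place: fluoro in place of methylamino on an aromatic carbon. Among the measured compounds shown here, no measured pair shows this change, so the direction can only be judged from the numbers at hand, where compound 1 with 1.2 nM and compound 2 with 14 nM both carry something other than methylamino there and lie lower. The step is expected to go down, by a 3.3-fold lower number from compound 3 to compound 4 (0.52 log units; beyond the scatter). Compound 4 is estimated at 12 nM, within 3 nM to 40 nM.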

Compound 4, inhibition constant: 19 nM
Beside the measured number, compound 4's estimate is 1.6-fold (0.20 log units) below it; measured number inside the range.
By their numbers in this assay, from the lowest: compound 1; then compounds 2 and 4 (each within the scatter of the next); then compound 3.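

In this assay, fluoro in place of methylamino on this aromatic carbon, two atoms from the ring nitrogen, gives a 2.1-fold lower number from compound 3 to compound 4 (0.32 log units; beyond the scatter), a modest step. This single change shows that the number here does not rise when the hydrogen-bond donor of methylamino is lost, as fluoro has none. Nothing at hand explains the step.

On these data alone, whether the donor itself matters or only the identity of the group stays open. Neither a methoxy group nor a plain amino group at this place appears among the compounds shown, and compounds 1 and 2 differ from compound 4 in more than one place.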